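A few compounds are considered here, and "the series" means these few. Any claim that something is new, unique, unknown or untested is made for them only; others in the source may bear on it.

In a functional assay on CAPAN-1 cells (Homo sapiens) for antiproliferative activity, with a stated time of 72 h (on this read-out higher numbers stand for weaker inhibition and lower numbers for stronger inhibition), the measured compounds read as follows.
Compound 1 `CCCCC#Cc1cc([C@@H]2O[C@H](CO)[C@@H](O)[C@H]2O)n2ncnc(N)c12` gives 1000 nM here
Compound 2 `Nc1ncnn2c([C@@H]3O[C@H](CO)[C@@H](O)[C@H]3O)cc(C#Cc3ccc(F)cc3)c12` gives 55400 nM here
Compound 3 `Nc1ncnn2c([C@@H]3O[C@H](CO)[C@@H](O)[C@H]3O)cc(C#Cc3ccccc3)c12` gives 37700 nM here

Compound 3 lies within the scatter of compound 2, with a 1.5-fold lower number from compound 2 to compound 3 (0.17 log units; within the scatter) between them. It stands far from compound 1, with a 38-fold higher number from compound 1 to compound 3 (1.58 log units; beyond the scatter) as the gap. For the measured compounds named here, compound 4 `Nc1ncnn2c([C@@H]3O[C@H](CO)[C@@H](O)[C@H]3O)cc(-c3ccccc3)c12` carries phenyl in place of 2-phenylethynyl on an aromatic carbon as its one difference from compound 3. Going by the values given here, no measured step removes the triple bond. The closest evidence is a 55-fold higher number from compound 1 to compound 2 (1.74 log units; beyond the scatter) and the gap already given, both large, so exchanging the group on the triple bond can move the number far. A moderate drop is therefore expected, though with wide uncertainty. The estimated change is a 3.1-fold lower number from compound 3 to compound 4 (0.50 log units; beyond the scatter) in this read-out. For compound 4 the estimate is 12000 nM as a middle value, with an expected range from 1500 nM to 60000 nM around it.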

Compound 4, half-maximal inhibitory concentration: 65200 nM
Compound 4: middle estimate off by 5.4-fold (0.74 log units), on the low side; measured number above the stated range.
By their numbers in this assay, from the lowest: compound 1; then compounds 3, 2 and 4 (each within the scatter of the next).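

In this assay, phenyl set directly on the aromatic carbon cannot be told apart from either aryl-bearing alkyne, with a 1.7-fold higher number from compound 3 to compound 4 (0.24 log units; within the scatter) and a 1.2-fold higher number from compound 2 to compound 4 (0.07 log units; within the scatter). The triple bond therefore makes no readable difference when an aromatic ring is attached at this position, while hex-1-yn-1-yl stands apart from phenyl, with a 65-fold higher number from compound 1 to compound 4 (1.81 log units; beyond the scatter). Nothing available explains this pattern.

The compounds shown leave open whether a saturated hexyl chain at this position would read like compound 1 or compound 4. They also leave open how a shorter or longer alkyl chain on the triple bond, or one ending in an amine, would read.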